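Adding an allyl group to a low-dose amine

This account rests on a few compounds, and the source may have more. Where it says the series, first, only, none or still open, it means among the compounds named here.

Compound 1 `CCC(=O)N(c1ccc(F)cc1)C1CCCC1N(C)C`: 5 mg/kg
Compound 2 `CCC(=O)N(c1ccc(Cl)c(Cl)c1)C1CCCC1N`: 0.02 mg/kg

Within the data shown here, in a functional assay on the whole organism for positive allosteric modulation, with Mus musculus as the target (on this read-out higher numbers stand for an effect only at larger amounts of compound and lower numbers for an effect already at smaller amounts), compound 2 gives 0.02 mg/kg, the lower of the only two numbers available. Compound 1 gives 5 mg/kg, a gap well beyond the usual scatter. Among the measured compounds shown here, no two measured compounds differ in just one place, so no measured step shows what a change on this nitrogen does.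

The next compound, compound 3 `C=CCNC1CCCC1N(C(=O)CC)c1ccc(Cl)c(Cl)c1`, keeps the rest of compound 2 and changes one thing: allyl in place of hydrogen on an amine nitrogen. It carries allyl in place of hydrogen on an amine nitrogen, so amino becomes allylamino.

Since compound 2 stands at 0.02 mg/kg, the lowest number seen so far, a single change seems more likely to raise the dose than to lower it. This is only a weak guide, and a result within the scatter remains possible. The expected result is a moderate rise in this assay, a 5.0-fold higher number from compound 2 to compound 3 (0.70 log units; beyond the scatter). For compound 3 the estimated dose is 0.1 mg/kg, with an expected range from 0.02 mg/kg to 0.6 mg/kg.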

Compound 3, dose for half-maximal effect: 0.2 mg/kg
Compound 3: the middle estimate sits 2.0-fold (0.30 log units) below what was measured; the range from low to high includes it.
By their numbers in this assay, from the lowest: compound 2; then compound 3; then compound 1.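

Among these compounds, this is the first step where only one place changes, so it gives the first direct reading of this amine nitrogen: in this assay, allyl in place of hydrogen brings a 10-fold higher number from compound 2 to compound 3 (1.00 log units; beyond the scatter). The step lies beyond the usual scatter, which means that this nitrogen is not a spot where a group can be added without consequence, and that on this core the plain amino group of compound 2 works at a smaller dose than the allylamino group of compound 3. The data show only the size and direction of this change, and nothing measured here accounts for it.

A single step cannot separate the effect of the double bond in allyl from that of simply having a carbon chain on this nitrogen, and a saturated propyl group or a longer butyl chain in the same place would help to tell these apart. Also open, as far as these compounds go, is whether allyl would bring a similar rise with the fluorine of compound 1 on the core in place of the two chlorines of compound 2.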